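Sulfamoyl in Place of Methoxy: An Expected Step

The compounds below may be only part of what the source reports. "The series", "measured", "known", "first", "only" and "open" are said of these compounds alone.

compound 1, `N#CC1=C(N)Oc2c(c3nc4ccccc4nc3c3ccccc23)C12C(=O)N(Cc1cnnn1-c1cccc(Cl)c1)c1ccccc12`, in a functional assay on A549 cells (Homo sapiens) for antiproliferative activity, read by MTT assay, with a stated time of 48 h; on this read-out higher numbers stand for weaker inhibition and lower numbers for stronger inhibition: 32600 nM
compound 2, `N#CC1=C(N)Oc2c(c3nc4ccccc4nc3c3ccccc23)C12C(=O)N(Cc1cnnn1-c1ccccc1Br)c1ccccc12`, in this assay: > 50000 nM
compound 3, `COc1ccc(-n2nncc2CN2C(=O)C3(C(C#N)=C(N)Oc4c3c3nc5ccccc5nc3c3ccccc43)c3ccccc32)cc1`, in this assay: > 50000 nM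

Compound 3 stands at a limit of this assay rather than at a number. Compound 2 sits at the same limit, so two of the three values shown are limits (the limit of > 50000 nM in this assay, at which 2 of the 3 values shown sit). Only compound 1 gives a number, and from it the steps of an at least 1.5-fold higher number from compound 1 to compound 2 (0.18 log units; that floor lies within the scatter) and an at least 1.5-fold higher number from compound 1 to compound 3 (0.18 log units; that floor lies within the scatter) are read as floors only; the step that the two limits leave unreadable from compound 2 to compound 3 cannot be read at all.

Compound 4, `N#CC1=C(N)Oc2c(c3nc4ccccc4nc3c3ccccc23)C12C(=O)N(Cc1cnnn1-c1ccc(S(N)(=O)=O)cc1)c1ccccc12`, differs from compound 3 in one place: sulfamoyl in place of methoxy on an aromatic carbon. The measured steps that bear on this are the three exchanges of the aryl group on the aromatic nitrogen named above, and none of them shows a movement that rises above the scatter or even a readable size. There is therefore no basis to expect a step in this assay from compound 3 to compound 4 beyond the scatter, in either direction, and the most likely outcome for compound 4 is again a limit. The estimate for compound 4 is 60000 nM, with a range from 20000 nM to 200000 nM, which means an expected step that the limit leaves unreadable from compound 3 to compound 4.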

Compound 4, half-maximal inhibitory concentration: > 50000 nM
Compound 4: only a limit was reported; the forecaster's own chance of this, stated with the estimate: 70%; the middle value does not contradict the limit.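

Compound 4 is one more compound that stands at a limit in this assay, so the sulfamoyl group, para to a large group, gives no more of a number than methoxy did in the same place. Among the compounds shown here, the steps to compound 4 from compound 3 and from compound 2 cannot be read, and the only step that can be read is an at least 1.5-fold higher number from compound 1 to compound 4 (0.18 log units; that floor lies within the scatter). What this result adds is therefore not a size of change but the spread of the limit across the series, which now covers every aryl group shown on the aromatic nitrogen except the 3-chlorophenyl of compound 1: the limit of > 50000 nM in this assay, at which 3 of the 4 values shown sit.

From the compounds shown here alone, whether sulfamoyl and methoxy differ at all in this place stays open, since neither compound 3 nor compound 4 gives a number to compare. Also open, going by these compounds, is whether an amine or a carboxylic acid on this aromatic carbon, in place of sulfamoyl, would give a number in this assay rather than another limit.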